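Chlorine on the Outer Phenyl: Compound 3 to Compound 4

This account rests on a few compounds, and the source may have more. Where it says the series, first, only, none or still open, it means among the compounds named here.

Three sulfonamides sharing one core were tested in a functional assay on HepG2 cells (Homo sapiens) for antiproliferative activity, read by MTT assay, with a stated time of 24 h; on this read-out lower numbers stand for stronger inhibition and higher numbers for weaker inhibition. Compound 1 `Cc1ccccc1-n1cc(-c2ccccc2NS(=O)(=O)c2c[nH]c(=O)[nH]c2=O)nn1` gives 13900 nM. Compound 2 `O=c1[nH]cc(S(=O)(=O)Nc2cccc(-c3cn(-c4cccc(Cl)c4)nn3)c2)c(=O)[nH]1` gives 4200 nM. Compound 3 `O=c1[nH]cc(S(=O)(=O)Nc2ccc(-c3cn(-c4ccccc4)nn3)cc2)c(=O)[nH]1` gives 18000 nM, the highest of the three numbers; its nearest neighbour is compound 1, whose number lies within the scatter of it, while compound 2 sits furthest away, beyond the scatter, with the lower number.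

Compound 4 `O=c1[nH]cc(S(=O)(=O)Nc2ccc(-c3cn(-c4ccccc4Cl)nn3)cc2)c(=O)[nH]1` has not been measured in this assay. It differs from compound 3 in one place: chloro in place of hydrogen on an aromatic carbon, which, read one bond further out, is phenyl to 2-chlorophenyl. Going by the values given here, no pair of measured compounds shows this single change alone, so its effect is unknown here. On the spread of the three numbers, a small step toward a lower number is expected from compound 3 to compound 4, a 2.0-fold lower number from compound 3 to compound 4 (0.30 log units; within the scatter), at or near the edge of the scatter. Compound 4 is therefore estimated at 9000 nM, with a range from 3000 nM to 25000 nM.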

Compound 4, half-maximal inhibitory concentration: 2230 nM
Compound 4: the middle estimate sits 4.0-fold (0.61 log units) above what was measured, outside the stated range (below it).
By their numbers in this assay, from the lowest: compounds 4 and 2 (each within the scatter of the next); then compounds 1 and 3 (each within the scatter of the next).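

In this assay, putting chloro in place of hydrogen on the outer phenyl gives an 8.1-fold lower number from compound 3 to compound 4 (0.91 log units; beyond the scatter), a step beyond the scatter. Going by these compounds alone, this is the first pair here that differs in one place only, and it shows that this aromatic carbon is not indifferent to substitution: a single chlorine atom, adding no ring and no hydrogen-bond donor or acceptor, is enough to move the number. Nothing in the data given explains why the step occurs.

As far as these compounds go, what a fluoro, methyl, methoxy or amine group would do on the same carbon stays open, so the step cannot yet be assigned to chlorine rather than to any group there. Also open, from the compounds shown here alone, is how chloro would act on the other carbons of that phenyl with the rest of compound 4 unchanged.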